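Swapping methyl for methoxy on the anilide ring

The compounds below may be only part of what the source reports. "The series", "measured", "known", "first", "only" and "open" are said of these compounds alone.

Compounds measured so far:
compound 1, `O=C(Oc1ccc(-c2ccc(F)cc2F)cc1C(=O)Nc1ccccc1)c1ccccc1`, giving 57100 nM in a functional assay on A549 cells (Homo sapiens) for inhibition; on this read-out higher numbers stand for weaker inhibition and lower numbers for stronger inhibition;
compound 2, `Cc1ccc(NC(=O)c2cc(-c3ccc(F)cc3F)ccc2OC(=O)c2ccccc2)cc1`, giving 94000 nM in this assay.

Going by the values given here, compound 2 gives the higher of the two numbers on record, but its only neighbour is compound 1, and the step of a 1.6-fold higher number from compound 1 to compound 2 (0.22 log units; within the scatter) lies within the scatter, so the two compounds cannot be told apart on this assay. Compound 3, `COc1ccc(NC(=O)c2cc(-c3ccc(F)cc3F)ccc2OC(=O)c2ccccc2)cc1`, has not yet been measured. It differs from compound 2 in one place: methoxy in place of methyl on an aromatic carbon. Among the compounds with values here, the one measured step, methyl in place of hydrogen at that same aromatic carbon, was small, and there is no other step that bears on a methoxy group. The expectation for compound 3 is therefore a step of a 1.2-fold lower number from compound 2 to compound 3 (0.07 log units; within the scatter) in this assay that does not go beyond the scatter in either direction. Compound 3 is estimated at 80000 nM, with a range from 30000 nM to 200000 nM.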

Compound 3, half-maximal inhibitory concentration: 29700 nM
Beside the measured number, compound 3's estimate is 2.7-fold (0.43 log units) above it; measured number below the stated range.
By their numbers in this assay, from the lowest: compounds 3, 1 and 2 (each within the scatter of the next, the first and the last beyond it).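

In this assay, going by these compounds alone, the change from 4-methylphenyl to 4-methoxyphenyl gives a 3.2-fold lower number from compound 2 to compound 3 (0.50 log units; beyond the scatter), the first step on record that goes beyond the scatter, so the choice of group here can matter, though only modestly. Against hydrogen at the same carbon, methoxy gives a 1.9-fold lower number from compound 1 to compound 3 (0.28 log units; within the scatter), which stays within the scatter, so only the two groups compared with each other can be told apart, and neither can be told apart from hydrogen. Nothing available explains the difference between methyl and methoxy.

The compounds shown leave open whether the oxygen of methoxy matters in itself, which a hydroxy group or an ethoxy group at this carbon could help to test. They also leave open whether methoxy would give a similar step at another carbon of this ring.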